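A few compounds are considered here, and "the series" means these few. Any claim that something is new, unique, unknown or untested is made for them only; others in the source may bear on it.

The measured compounds:

compound 1, `CCCn1c(SCc2cc([N+](=O)[O-])ccc2OC)nc2cc(NC(=O)NC(C)(C)C)ccc21`, 18 nM
compound 2, `CCCn1c(SCc2cc([N+](=O)[O-])ccc2OC)nc2cc(NC(=O)NC(C)(C)C)cc(C(=O)NC(C)(C)C)c21`, 410 nM

In an assay on isolated protein for inhibition of Gonadotropin-releasing hormone receptor (Homo sapiens) (a higher number here means a weaker inhibitor, a lower number a stronger inhibitor), compound 2 gives the higher of the two numbers; its nearest neighbour is compound 1, and the step of a 23-fold higher number from compound 1 to compound 2 (1.36 log units; beyond the scatter) is the only measured change among these compounds. Compound 3, `CCCn1c(SCc2cc([N+](=O)[O-])ccc2OC)nc2cc(NC(=O)NC(C)(C)C)cc(C(=O)NCc3cccnc3)c21`, carries the change ((pyridin-3-yl)methyl in place of tert-butyl on an amide-type nitrogen). That measured step does not bear on this exchange: it concerns the entry of the whole (tert-butyl)carbamoyl group onto the shared core, not what sits on its amide-type nitrogen. Within the data shown here, with no step touching that position, he has no ground for expecting movement beyond the usual scatter in this assay in either direction. His estimate for compound 3 is therefore 400 nM, within 130 nM to 1200 nM. The step this estimate means, a 1.0-fold lower number from compound 2 to compound 3 (0.01 log units; within the scatter), is expected to stay within the scatter.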

Compound 3, half-maximal inhibitory concentration: 69 nM
Beside the measured number, compound 3's estimate is 5.8-fold (0.76 log units) above it; the measured number lies below the stated range.
By their numbers in this assay, from the lowest: compound 1; then compound 3; then compound 2.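

In this assay the group on the amide-type nitrogen proves to matter: (pyridin-3-yl)methyl in place of tert-butyl gives a 5.9-fold lower number from compound 2 to compound 3 (0.77 log units; beyond the scatter), so the loss seen when the (tert-butyl)carbamoyl group entered does not belong to the carbamoyl unit as a whole. Measured against hydrogen on the aromatic carbon, the ((pyridin-3-yl)methyl)carbamoyl group still gives a 3.8-fold higher number from compound 1 to compound 3 (0.58 log units; beyond the scatter), so the exchange recovers only part of that loss, and compound 1 stays the lowest of the three. Nothing given here accounts for the size of either step.

The compounds shown leave open whether the gain depends on the ring nitrogen or on the aromatic ring alone, which a benzyl group on the same nitrogen would help separate. Going by these compounds, it is also open whether a pyridin-4-ylmethyl group or a simple amine-bearing chain there would close the remaining gap to compound 1.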